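Cyclopropyl in Place of Methyl on the Shared Core

The source may hold more compounds than are shown below. What is called first, only, known or untested is meant among the compounds shown, and "the series" means these compounds.

Of the compounds shown here, three of the shared core have been measured in an ADME assay on microsomes from liver (Homo sapiens) for metabolic stability, with a stated time of 30 min, tested at 2 uM, in the presence of a further agent that is not named here; on this read-out higher numbers stand for a more stable compound and lower numbers for a less stable compound. Compound 1 `CC1(C)C(=O)c2[nH]ncc2C(C2CC2)N1S(=O)(=O)c1ccc(C(F)(F)F)cc1` gives 67%. Compound 2 `CC1C(=O)c2[nH]ncc2C(C2CC2)N1S(=O)(=O)c1ccc(C(F)(F)F)cc1`, in this assay, gives 67%, and compound 3 `CC1C(=O)c2[nH]ncc2C(C)N1S(=O)(=O)c1ccc(C(F)(F)F)cc1` gives 77%. Compound 2 stands level with compound 1, as no change at the digits printed from compound 1 to compound 2 (within the scatter) shows, and the gap to compound 3, a number 10 percentage points higher from compound 2 to compound 3 (within the scatter), stays within the scatter as well.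

Compound 4 `O=C1c2[nH]ncc2C(C2CC2)N(S(=O)(=O)c2ccc(C(F)(F)F)cc2)C1C1CC1` has not yet been measured. Its difference from compound 2 is cyclopropyl in place of methyl on a saturated ring carbon. Among the compounds with values here, two measured steps bear on this change. The first, no change at the digits printed from compound 1 to compound 2 (within the scatter), removes a methyl on a saturated ring carbon and leaves the read-out unmoved. The second, a number 10 percentage points higher from compound 2 to compound 3 (within the scatter), is the mirror of the present exchange on another saturated ring carbon of the same ring, and it too stays within the scatter. Neither step hints at a movement beyond the scatter for compound 4 in this assay; if anything, the reverse of a number 10 percentage points higher from compound 2 to compound 3 (within the scatter) points slightly downward.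

The expected step is therefore a number 5 percentage points lower from compound 2 to compound 4 (within the scatter). Compound 4 is estimated to give 62% in this assay, with a range of 48% to 76%.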

Compound 4, percent of the compound remaining: 76%
Compound 4: middle estimate off by 14 percentage points, on the low side, and the stated range covers the measured number.
By their numbers in this assay, from the lowest: compounds 1, 2, 4 and 3 (each within the scatter of the next).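

In this assay, putting cyclopropyl in place of methyl on this saturated ring carbon, next to the ring nitrogen and next to the ring atom that bears a large group, gives a number 9 percentage points higher from compound 2 to compound 4 (within the scatter) and so stays inside the usual variation of the measurement. Within the data shown here, until now, this position had been seen only with methyl groups, one or two of them, with no change at the digits printed from compound 1 to compound 2 (within the scatter) as the only step there; the new result extends the comparison to a group of 3 heavy atoms carrying a three-membered ring, and the read-out again shows no step beyond the scatter. No measurement among the data shown explains this result or says what the cyclopropyl group does at this position.

The compounds shown leave open whether an amine, a carboxylic acid or a longer chain such as n-butyl on this ring carbon would also stay within the scatter. They also leave open how cyclopropyl at this position would read with methyl rather than cyclopropyl on the other saturated ring carbon, since both compounds in this step carry cyclopropyl there.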